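A ring swap from compound 2 to compound 3

This account rests on a few compounds, and the source may have more. Where it says the series, first, only, none or still open, it means among the compounds named here.

compound 1 `Clc1cccc(-n2ncnc2Nc2ccccc2)c1Cl`: 363 nM
compound 2 `Clc1cccc(-n2ncnc2NCc2ccccc2)c1Cl`: 47.9 nM

Within the data shown here, in a functional assay for antagonist activity at P2X purinoceptor 7 (Homo sapiens), read by FLIPR and calcium flux (a lower number here means a stronger inhibitor, a higher number a weaker inhibitor), compound 2 gives the lower of the two numbers, and the single measured step, a 7.6-fold lower number from compound 1 to compound 2 (0.88 log units; beyond the scatter), separates it from compound 1. Compound 3 `Clc1cccc(-n2ncnc2NCc2cccnc2)c1Cl` differs from compound 2 by pyridin-3-yl in place of phenyl on a saturated chain carbon bound to a nitrogen on an aromatic ring. Among the measured compounds shown here, the step of a 7.6-fold lower number from compound 1 to compound 2 (0.88 log units; beyond the scatter) concerns a different part of the molecule, so no measured pair speaks to this change. Compound 3 is therefore expected to stay close to compound 2, with an estimated step of a 1.5-fold higher number from compound 2 to compound 3 (0.16 log units; within the scatter), not beyond the scatter. The estimate for compound 3 is 70 nM, within 20 nM to 250 nM.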

Compound 3, half-maximal inhibitory concentration: 117 nM
For compound 3 the middle estimate is 1.7-fold (0.22 log units) below the measured one, and the stated range covers the measured number.
By their numbers in this assay, from the lowest: compound 2; then compound 3; then compound 1.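

In this assay, the ring on the saturated chain carbon proves sensitive to a single change of ring atom: pyridin-3-yl in place of phenyl gives a clear loss (a 2.4-fold higher number from compound 2 to compound 3 (0.39 log units; beyond the scatter)). Part of the gain seen with the benzyl group survives this change, with (pyridin-3-yl)methyl in place of phenyl on the nitrogen still giving a 3.1-fold lower number from compound 1 to compound 3 (0.49 log units; beyond the scatter). No available evidence accounts for the difference between the two rings. The compounds shown leave open how a longer chain such as phenethyl in place of benzyl, or a methoxy group on the phenyl ring, would read in this assay.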